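A New Sulfur-Chain Group After Two Assay Limits

The compounds below may be only part of what the source reports. "The series", "measured", "known", "first", "only" and "open" are said of these compounds alone.

Compound 1 `CCSc1nnc(-c2cc(OC)c(OC)c(OC)c2)n1-c1ccc(OC)cc1`: > 60000 nM, a limit
Compound 2 `COc1ccc(CSc2nnc(-c3cc(OC)c(OC)c(OC)c3)n2-c2ccc(OC)cc2)cc1`: > 60000 nM, a limit

Both entries come from a functional assay on HT-29 cells (Homo sapiens) for inhibition, read by MTT assay, with a stated time of 48 h (on this read-out lower numbers stand for stronger inhibition and higher numbers for weaker inhibition), and neither is a true number. Together they show (the limit of > 60000 nM in this assay, at which 2 of the 2 values shown sit). Among the compounds with values here, the only measured step is a step that the two limits leave unreadable from compound 1 to compound 2. It therefore offers no size to carry forward.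

Compound 3 `COc1ccc(-n2c(SCC(=O)c3ccc(F)cc3)nnc2-c2cc(OC)c(OC)c(OC)c2)cc1` keeps the shared core of compound 2 and changes one group: (4-fluorophenyl)carbonyl in place of 4-methoxyphenyl on a saturated chain carbon bound to a sulfur. Counted one bond further out, 4-methoxybenzyl gives way to ((4-fluorophenyl)carbonyl)methyl. Within the data shown here, the carbonyl is new to this small set, and no measured step tests it.

The expectation rests on compound 2 at > 60000 nM, a limit. In this assay, a large step is not expected, although a modest move toward stronger inhibition remains possible, and compound 3 may well return only a limit too. The expected size is an at least 1.3-fold lower number from compound 2 to compound 3 (0.12 log units; that floor lies within the scatter). For compound 3 the estimated value is 45000 nM, with an expected range from 10000 nM to 100000 nM.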

Compound 3, half-maximal inhibitory concentration: 42500 nM
Beside the measured number, compound 3's estimate is 1.1-fold (0.02 log units) above it; low and high end bracket the measured number.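

Compound 3 gives this small set its first true number in this assay, so a change on the saturated chain carbon bound to a sulfur can now be given a direction and not just a shared limit. From the compounds shown here alone, putting (4-fluorophenyl)carbonyl in place of 4-methoxyphenyl gives an at least 1.4-fold lower number from compound 2 to compound 3 (0.14 log units; that floor lies within the scatter), and putting the same group in place of methyl gives an at least 1.4-fold lower number from compound 1 to compound 3 (0.14 log units; that floor lies within the scatter); each is only a floor, so the full size of either step stays unknown. The step between the other two compounds still cannot be read, since both stop at the same ceiling: the limit of > 60000 nM in this assay, at which 2 of the 3 values shown sit.

The change from compound 2 to compound 3 brings in the carbonyl and also swaps the methoxy on the ring for a fluorine, so the compounds shown cannot say which of these two differences goes with the lower number. Also open, going by these compounds, is how the same chain carbon would respond to a different kind of group, such as an amine, a carboxylic acid or a longer chain, and whether any of these would reach numbers clearly beyond the scatter.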